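The source may hold more compounds than are shown below. What is called first, only, known or untested is meant among the compounds shown, and "the series" means these compounds.

Compound 3, `COc1ccc(C(=O)Nc2nc(-c3ccccc3)cn3cc(-c4ccccc4)nc23)cc1`, stands at the low end of the three measured numbers. In an assay on cells for displacement of a labelled ligand from transmembrane domain-containing protein TMIGD3 (Homo sapiens), read by scintillation counting, with a stated time of 120 min (on this read-out lower numbers stand for stronger inhibition and higher numbers for weaker inhibition), compound 3 gives 25 nM. Compound 1, `O=C(c1ccccc1)N(C(=O)c1ccccc1)c1nccn2cc(-c3ccccc3)nc12`, gives 64 nM in this assay, and compound 2, `COc1ccc(-c2cn3ccnc(NC(=O)c4ccccc4)c3n2)cc1`, gives 121 nM; both gaps to compound 3 lie beyond the usual scatter, so compound 3 carries the strongest binding of the three. Compound 4, `O=C(Nc1nc(-c2ccccc2)cn2cc(-c3ccccc3)nc12)c1ccc(F)cc1`, has not yet been measured. It differs from compound 3 in one place: fluoro in place of methoxy on an aromatic carbon, on an aromatic carbon of a six-membered aromatic ring of carbon only, para to a large group. For the measured compounds named here, no measured pair in this set isolates that exchange, so there is no direct step to lean on; the three measured compounds differ from one another in the acyl part and in the substituent on the shared core in other ways. A small exchange of this kind is expected to shift the inhibition constant only modestly, and the expected step from compound 3 to compound 4 is a 1.6-fold higher number from compound 3 to compound 4 (0.20 log units; within the scatter), a slight weakening that may not exceed the scatter. Compound 4 is therefore estimated at 40 nM in this assay, with a range from 15 nM to 110 nM.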

Compound 4, inhibition constant: 38 nM
For compound 4 the middle estimate is 1.1-fold (0.02 log units) above the measured one, within the range that was stated.
By their numbers in this assay, from the lowest: compounds 3, 4, 1 and 2 (each within the scatter of the next, the first and the last beyond it).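

For the compounds shown here, the exchange of (4-methoxyphenyl)carbonyl for (4-fluorophenyl)carbonyl gives the first direct reading at this position: in this assay it is a 1.5-fold higher number from compound 3 to compound 4 (0.18 log units; within the scatter), so the two compounds cannot be told apart. At this place, on an aromatic carbon para to a large group, methoxy can therefore give way to fluoro, with one heavy atom in place of two and without the hydrogen-bond acceptor counted for methoxy, and the read-out separates the result from neither compound. No measured property bears on this result, so it stands as an observation without an explanation.

The compounds shown cover only methoxy and fluoro at this place, so it stays open whether an amine, a carboxylic acid, a chloro group or a longer chain such as ethoxy would also stay within the scatter of compound 3. Going by these compounds, it also stays open whether fluoro in place of methoxy would read the same on the methoxy-bearing ring of compound 2, where the surrounding structure differs.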